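Toluenesulfonyl-piperazine amides: stereochemical variation at the chain carbon

The compounds below may be only part of what the source reports. "The series", "measured", "known", "first", "only" and "open" are said of these compounds alone.

Measured compounds:
compound 1 `CC(C(=O)N1Cc2ccccc2C1)N1CCN(S(=O)(=O)c2ccc(C(C)(C)C)cc2)CC1` — > 40000 nM
compound 2 `CC(C(=O)N1CCc2ccccc2C1C)N1CCN(S(=O)(=O)c2ccc(C(C)(C)C)cc2)CC1` — 28000 nM
compound 3 `C[C@@H](C(=O)N1CCc2ccccc2C1(C)C)N1CCN(S(=O)(=O)c2ccc(C(C)(C)C)cc2)CC1` — 26000 nM

In an ADME assay on HepG2 cells (Homo sapiens) for inhibition, with a stated time of 48 h (on this read-out higher numbers stand for an effect only at larger amounts of compound and lower numbers for an effect already at smaller amounts), compound 1 gives only a limit, > 40000 nM (the limit of > 40000 nM in this assay, at which 1 of the 3 values shown sits). Compound 2 gives 28000 nM in this assay, and compound 3 gives 26000 nM; these two numbers lie within the scatter of each other, so neither compound can be set apart from the other. For the measured compounds named here, the one measured step, an at least 1.4-fold lower number from compound 1 to compound 2 (0.15 log units; that floor lies within the scatter), reaches only a floor that sits within the scatter and therefore carries no direction.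

Compound 4 `CC(C(=O)N1CCc2ccccc2C1(C)C)N1CCN(S(=O)(=O)c2ccc(C(C)(C)C)cc2)CC1` is the next member. Its difference from compound 3 is the two compounds have the same atoms and bonds; at least one stereo element is drawn with a configuration in one of them and without one in the other: 1 of 1 stereo elements differ; a stereocentre at a saturated chain carbon is drawn S in compound 3 and without a configuration in compound 4: the two compounds have the same atoms and bonds, and the stereocentre at the saturated chain carbon that is drawn S in compound 3 is drawn without a configuration in compound 4. No measured step in this set changes a stereo element alone, so nothing shown bears directly on it. Given that the numbers for compound 2 and compound 3 sit close together and that compound 1 reaches a limit, no movement beyond the scatter is expected for the step of a 1.2-fold higher number from compound 3 to compound 4 (0.06 log units; within the scatter). For compound 4 the estimate in this assay is 30000 nM, with a range from 15000 nM to 60000 nM.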

Compound 4, half-maximal effective concentration: 31000 nM
For compound 4 the middle estimate is 1.0-fold (0.01 log units) below the measured one; low and high end bracket the measured number.
By their numbers in this assay, from the lowest: compounds 3, 2 and 4 (each within the scatter of the next). At a limit, above all of these: compound 1.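

In this assay, for the compounds shown here, the step of a 1.2-fold higher number from compound 3 to compound 4 (0.08 log units; within the scatter) gives the first reading at the stereocentre on the saturated chain carbon, and it stays within the scatter, so the S drawing and the undefined drawing cannot be told apart here. This reading compares a defined drawing with an undefined one rather than two opposite configurations, and it has to be taken with this limitation: the fact that one of compounds 3 and 4 is drawn with a defined configuration and the other without, at the place where they differ The step of a 1.1-fold higher number from compound 2 to compound 4 (0.04 log units; within the scatter), methyl in place of hydrogen on a saturated ring carbon, also stays within the scatter, so this change shows no readable effect on the number in this assay.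

The compounds shown leave open whether a chain carbon drawn R would give a number set apart from that of compound 3. They also leave open whether an amine or a carboxylic acid in place of methyl on the saturated ring carbon would move the number in this assay beyond the scatter.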